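This account rests on a few compounds, and the source may have more. Where it says the series, first, only, none or still open, it means among the compounds named here.

Working notes on the series. The series is followed in an ADME assay on TZM-b1 cells (Homo sapiens) for cytotoxicity, read by XTT assay, with a stated time of 3 days; a lower number here means that less compound is tolerated, a higher number that more compound is tolerated. Compound 1, `Cc1ccc(NC(=O)C(=O)NC(c2nc(C)c(CCO)s2)C2CCCCN2)cc1F`, sits at the limit of this assay: in this assay compound 1 gives > 85000 nM, which is a limit of the assay and not a number. The evidence on this point is the limit of > 85000 nM in this assay, at which 1 of the 2 values shown sits. Compound 2, `CCn1cc(NC(=O)C(=O)Nc2ccc(Cl)cc2)cn1`, has a different core; in this assay compound 2 gives 8000 nM. Among the compounds with values here, no step between measured compounds that differ in one place is known, so the step to compound 3 rests on the structural change alone. Compound 3, `Cc1nc(C(NC(=O)C(=O)Nc2ccc(F)c(Cl)c2)C2CCCCN2)sc1CCO`, differs from compound 1 by 3-chloro-4-fluorophenyl in place of 3-fluoro-4-methylphenyl on an amide-type nitrogen. In this assay the step from compound 1 to compound 3 is expected to be a number no higher from compound 1 to compound 3 (the limit leaves the size open), that is, no shift beyond the usual scatter in either direction. Compound 3 is therefore estimated at 85000 nM in this assay, with a range from 30000 nM to 200000 nM, and most likely the assay again reports only a limit.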

Compound 3, half-maximal cytotoxic concentration: > 75800 nM
Compound 3 was reported as a limit; the forecaster's own chance of this, stated with the estimate: 65%; the middle value lies beyond the limit too.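

In this assay, within the data shown here, compound 1 and compound 3 both stand as limits of the assay and not as numbers, so no step between them can be read. The compounds shown leave open whether 3-chloro-4-fluorophenyl in place of 3-fluoro-4-methylphenyl shifts the half-maximal cytotoxic concentration at all.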